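A few compounds are considered here, and "the series" means these few. Any claim that something is new, unique, unknown or untested is made for them only; others in the source may bear on it.

Measured in an ADME assay on 2209-23 cells (Homo sapiens) for cytotoxicity, read by WST assay and thymidine incorporation (on this read-out lower numbers stand for higher toxicity in this test and higher numbers for lower toxicity in this test), each value being a limit and not a number:

- Compound 1 `CC(C)(C)CCN1C(=O)C(C2=CS(=O)(=O)c3cc(NS(C)(=O)=O)ccc3N2)=C(O)[C@@H]1C(C)(C)C`: > 50000 nM
- Compound 2 `CC(C)(C)[C@H]1C(O)=C(C2=CS(=O)(=O)c3cc(NS(C)(=O)=O)ccc3N2)C(=O)N1Cc1ccccc1`: > 50000 nM
- Compound 3 `COc1cc(CN2C(=O)C(C3=CS(=O)(=O)c4cc(NS(C)(=O)=O)ccc4N3)=C(O)[C@@H]2C(C)(C)C)ccc1F`: > 50000 nM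

Compound 3 stands at the limit of > 50000 nM in this assay, at which 3 of the 3 values shown sit. Compound 4 `CC(C)(C)[C@H]1C(O)=C(C2=CS(=O)(=O)c3cc(NS(C)(=O)=O)ccc3N2)C(=O)N1Cc1ccc(F)c(Cl)c1` carries chloro in place of the methoxy of compound 3, on an aromatic carbon ortho to a fluoro group, so 4-fluoro-3-methoxybenzyl becomes 3-chloro-4-fluorobenzyl (chloro in place of methoxy on an aromatic carbon). The closest measured change to this group is a step that the two limits leave unreadable from compound 2 to compound 3. Two more changes at the same place are a step that the two limits leave unreadable from compound 1 to compound 2 and a step that the two limits leave unreadable from compound 1 to compound 3. None has a readable size, yet none of these swaps brought a value off the limit, so no step beyond the usual scatter is expected. The expected change is a number no higher from compound 3 to compound 4 (the limit leaves the size open). For compound 4 the estimate is 50000 nM, with an expected range from 25000 nM to 100000 nM, and the assay will most likely report only a limit again.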

Compound 4, half-maximal cytotoxic concentration: > 50000 nM
Compound 4 ended at the assay's limit (the forecaster's own chance of this, stated with the estimate: 85%); the middle value lies on the limit itself.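

In this assay compound 4 gives > 50000 nM, a limit and not a number, and its steps from compound 1, compound 2 and compound 3 cannot be read. The compounds shown leave open at what concentration any of them becomes toxic to these cells, and whether these group swaps change that concentration.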